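Swapping the chain aryl in compound 4

This account rests on a few compounds, and the source may have more. Where it says the series, first, only, none or still open, it means among the compounds named here.

Compound 1 `COc1cc(/C=C/C(=O)c2cccc(-n3cc(-c4ccc(Cl)cc4)[nH]c3=O)c2)cc(OC)c1OC`: 3560 nM
Compound 2 `COc1cc(/C=C/C(=O)c2cccc(-n3cc(-c4ccccc4)[nH]c3=O)c2)cc(OC)c1OC`: 1430 nM
Compound 3 `COc1ccc(-c2cn(-c3cccc(C(=O)/C=C/c4ccc(O)c(OC)c4)c3)c(=O)[nH]2)cc1`: 2850 nM

In a functional assay on NCI-H23 cells (Homo sapiens) for inhibition (on this read-out lower numbers stand for stronger inhibition of growth and higher numbers for weaker inhibition of growth), compound 3 gives 2850 nM, the second highest of the three numbers, yet it lies within the scatter of compound 1 and of compound 2. Compound 4 `COc1ccc(-c2cn(-c3cccc(C(=O)/C=C/c4cc(OC)c(OC)c(OC)c4)c3)c(=O)[nH]2)cc1` keeps the core and the 4-methoxyphenyl of compound 3 and differs in one place: 3,4,5-trimethoxyphenyl in place of 4-hydroxy-3-methoxyphenyl on a double-bonded chain carbon bound to a double-bonded chain carbon. Going by the values given here, the only measured step, a 2.5-fold lower number from compound 1 to compound 2 (0.40 log units; beyond the scatter), concerns hydrogen in place of chloro on the other aromatic ring and so does not bear on this change. Compounds 1 and 2, which already carry the entering 3,4,5-trimethoxyphenyl, give numbers that bracket compound 3 in this assay, so no step beyond the scatter is expected here. The step from compound 3 to compound 4 is therefore estimated as a 1.1-fold higher number from compound 3 to compound 4 (0.02 log units; within the scatter). Compound 4 is expected to give about 3000 nM, within a range from 1000 nM to 9000 nM.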

Compound 4, concentration for 50% growth inhibition: 1630 nM
Beside the measured number, compound 4's estimate is 1.8-fold (0.26 log units) above it, and the stated range covers the measured number.
By their numbers in this assay, from the lowest: compounds 2, 4, 3 and 1 (each within the scatter of the next, the first and the last beyond it).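

In this assay, 3,4,5-trimethoxyphenyl in place of 4-hydroxy-3-methoxyphenyl on a double-bonded chain carbon bound to a double-bonded chain carbon gives a 1.7-fold lower number from compound 3 to compound 4 (0.24 log units; within the scatter), so this swap of the chain aryl is not resolved from the scatter. With 3,4,5-trimethoxyphenyl held fixed, the substituent on the other aromatic ring can now be read again: methoxy in place of hydrogen gives a 1.1-fold higher number from compound 2 to compound 4 (0.06 log units; within the scatter), while methoxy in place of chloro gives a 2.2-fold lower number from compound 1 to compound 4 (0.34 log units; beyond the scatter). Among these three compounds, hydrogen and methoxy on that ring are not told apart, and only the chloro compound stands apart from both.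

On these data alone, whether an amine or a carboxylic acid on the chain aryl would shift the number beyond the scatter stays open. Nothing available here explains why these numbers fall as they do.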